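Phenyl in place of hydrogen: expectation for compound 4

The source may report more compounds than this note shows. Statements on the series, on what has been measured and on what is new or still open speak of the compounds shown alone.

Compound 3 `CCCCCCCC/C=C\CCCCCCC(=O)c1ncco1` gives 17 nM in an assay on isolated protein for inhibition of Fatty-acid amide hydrolase 1 (Homo sapiens) (on this read-out higher numbers stand for weaker inhibition and lower numbers for stronger inhibition), the lowest of the three numbers. Compound 2 `CCCCCCCC/C=C\CCCCCCC(=O)c1ncc(-c2ccccn2)o1` gives 18 nM in this assay, and compound 1 `CCCCCCCC/C=C\CCCCCCC(=O)c1ncc(-c2ccoc2)o1` gives 610 nM. Between them, a 1.1-fold lower number from compound 2 to compound 3 (0.02 log units; within the scatter) lies within the scatter, whereas a 36-fold lower number from compound 1 to compound 3 (1.55 log units; beyond the scatter) and a 34-fold lower number from compound 1 to compound 2 (1.53 log units; beyond the scatter) are large. Compound 4 `CCCCCCCC/C=C\CCCCCCC(=O)c1ncc(-c2ccccc2)o1` introduces (phenyl in place of hydrogen on an aromatic carbon). This is the same ring carbon where pyridin-2-yl in compound 2 left the number unchanged and furan-3-yl in compound 1 raised it sharply. Compound 4 is therefore expected to show a step of a 2.4-fold higher number from compound 3 to compound 4 (0.37 log units; beyond the scatter), with a modest weakening or no change more likely than a large loss. Compound 4 is estimated at 40 nM, ranging from 15 nM to 300 nM.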

Compound 4, inhibition constant: 320 nM
Estimate against measurement, compound 4: 8.0-fold (0.90 log units) below, outside the stated range (above it).
By their numbers in this assay, from the lowest: compounds 3 and 2 (each within the scatter of the next); then compounds 4 and 1 (each within the scatter of the next).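

In this assay, phenyl on the aromatic carbon next to the ring oxygen costs far more than pyridin-2-yl at that carbon, with a 19-fold higher number from compound 3 to compound 4 (1.27 log units; beyond the scatter) and an 18-fold higher number from compound 2 to compound 4 (1.25 log units; beyond the scatter). Phenyl instead falls level with furan-3-yl, with a 1.9-fold lower number from compound 1 to compound 4 (0.28 log units; within the scatter), so the large loss is shared by two of the three substituted compounds, and compound 2 goes against it. Nothing shown here accounts for why compound 2 stands apart. Going by these compounds, whether pyridin-3-yl, pyridin-4-yl or a carboxylic acid at this carbon would behave like compound 2 or like compound 4 remains open.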